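Nitro in Place of Phenyl on the Chalcone Chain

The compounds below may be only part of what the source reports. "The series", "measured", "known", "first", "only" and "open" are said of these compounds alone.

Compound 1 `COc1ccc(/C=C/C(=O)c2ccc(OC)c3c2OC(C)(C)C=C3)c(F)c1` gives > 10000 nM in a functional assay on HT-29 cells (Homo sapiens) for antiproliferative activity, read by MTT assay, with a stated time of 24 h; on this read-out lower numbers stand for stronger inhibition and higher numbers for weaker inhibition.
Compound 2 `COc1ccc(C(=O)/C=C/c2ccc(N(C)C)cc2)c2c1C=CC(C)(C)O2` gives 1870 nM in this assay.
Compound 3 `COc1ccc(C(=O)/C=C/c2ccc(-c3ccccc3)cc2)c2c1C=CC(C)(C)O2` gives > 10000 nM in this assay.

The value of compound 3 is a limit of this assay, not a number. Two of the three measured values sit at this limit (the limit of > 10000 nM in this assay, at which 2 of the 3 values shown sit). Compound 2 is the only one of the three that returns a number in this assay. The two measured steps both reach beyond the scatter: an at least 5.3-fold lower number from compound 1 to compound 2 (0.72 log units; beyond the scatter) and an at least 5.3-fold higher number from compound 2 to compound 3 (0.72 log units; beyond the scatter). Going by the values given here, each step is at least modest, and in each the compound carrying dimethylamino is the one with a number.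

Compound 4 `COc1ccc(C(=O)/C=C/c2ccc([N+](=O)[O-])cc2)c2c1C=CC(C)(C)O2` differs from compound 3 in one place: nitro in place of phenyl on an aromatic carbon. Among the compounds with values here, neither measured step exchanges phenyl for nitro, so no direct precedent exists. What the steps do show is that a group other than dimethylamino in this position has, so far, gone together with a limit. Compound 4 is therefore expected to stay close to the limit of this assay, with a step of an at least 1.2-fold lower number from compound 3 to compound 4 (0.09 log units; that floor lies within the scatter) that may not register beyond the scatter. The estimate for compound 4 is 8000 nM, with a range from 2000 nM to 30000 nM.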

Compound 4, half-maximal inhibitory concentration: 3730 nM
For compound 4 the middle estimate is 2.1-fold (0.33 log units) above the measured one; measured number inside the range.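

Going by these compounds alone, at this position in this assay, dimethylamino is no longer the only group that goes with a number, as nitro in place of phenyl on the aromatic carbon gives an at least 2.6-fold lower number from compound 3 to compound 4 (0.42 log units; beyond the scatter). Nitro in place of dimethylamino gives a 2.0-fold higher number from compound 2 to compound 4 (0.30 log units; within the scatter), so these two groups cannot be told apart in this assay, while 4-nitrophenyl in place of 2-fluoro-4-methoxyphenyl on the chain gives an at least 2.6-fold lower number from compound 1 to compound 4 (0.42 log units; beyond the scatter). The two steps that reach beyond the scatter start from limits and not from numbers, so their true size stays unknown, and the compounds at the limit are those carrying phenyl on this aromatic carbon and 2-fluoro-4-methoxyphenyl on the chain: the limit of > 10000 nM in this assay, at which 2 of the 4 values shown sit.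

With only phenyl, nitro and dimethylamino shown on this aromatic carbon, the compounds leave open how a primary amine, a carboxylic acid or a nitrile would read out there. They also leave open whether the fluoro or the methoxy of compound 1 goes with its limit, a question that a plain 4-methoxyphenyl or 2-fluorophenyl group on the chain would address.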